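The source may hold more compounds than are shown below. What is called first, only, known or untested is meant among the compounds shown, and "the series" means these compounds.

Measured so far:
- Compound 1, `CCOC(=O)C1CCN(CCCCCCOc2ccc3oc(-c4ccccc4)cc(=O)c3c2)CC1`: 164 nM
- Compound 2, `O=c1cc(-c2cccs2)oc2ccc(OCCCCCCN3CCC(O)CC3)cc12`: 119 nM

Both compounds were tested in an assay on isolated protein (Cavia porcellus) with Sigma non-opioid intracellular receptor 1 (Homo sapiens) as the target, read by radioligand binding; a higher number here means a weaker inhibitor, a lower number a stronger inhibitor. Compound 1 gives 164 nM and compound 2 gives 119 nM. Compound 2 carries the lower of the two numbers, but its gap to compound 1 lies within the scatter of repeated measurements, so the two compounds cannot be told apart on this evidence.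

Compound 3, `O=c1cc(C2CCCCC2)oc2ccc(OCCCCCCN3CCC(O)CC3)cc12`, has not yet been measured in this assay. It differs from compound 2 in one place: cyclohexyl in place of thiophen-2-yl on an aromatic carbon. The shared core and the side chain that ends in the ring with the hydroxyl group are unchanged.

Within the data shown here, no measured pair shows what such a swap does here, so the expectation rests on the closeness of compound 1 and compound 2 alone. The step from compound 2 to compound 3 is expected to be small, a 1.3-fold higher number from compound 2 to compound 3 (0.13 log units; within the scatter), with no clear direction beyond the scatter. Compound 3 is therefore estimated at 160 nM, within a range from 50 nM to 500 nM.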

Compound 3, half-maximal inhibitory concentration: 88 nM
Beside the measured number, compound 3's estimate is 1.8-fold (0.26 log units) above it; the range from low to high includes it.
By their numbers in this assay, from the lowest: compounds 3, 2 and 1 (each within the scatter of the next).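

In this assay, the swap of thiophen-2-yl for cyclohexyl on the aromatic carbon next to the ring oxygen gives a 1.4-fold lower number from compound 2 to compound 3 (0.13 log units; within the scatter). Among these compounds, this is the first direct look at this position, and it shows that a five-membered aromatic ring with a sulfur atom and a six-membered non-aromatic ring of carbon only cannot be told apart here, even though the two groups differ in aromaticity, ring size and atom content. No measurement shown here accounts for this closeness.

Going by these compounds, it remains open whether a much smaller group at this position, such as methyl, would move the number beyond the scatter. The same question stands for a group carrying a carboxylic acid or an amine.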